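Extending the Chain Carbon of Compound 3

This account rests on a few compounds, and the source may have more. Where it says the series, first, only, none or still open, it means among the compounds named here.

Measured in a functional assay on T29Kt1 cells (Homo sapiens) for cytotoxicity, read by sulforhodamine B assay, with a stated time of 3 days; on this read-out lower numbers stand for stronger inhibition and higher numbers for weaker inhibition:
- Compound 1 `OCc1cn(Cc2ccc(Cl)cc2)c2ccccc12`: 79 nM
- Compound 2 `OCCc1cn(Cc2ccc(Cl)cc2)c2ccccc12`: > 31600 nM (a limit)
- Compound 3 `Cc1cn(Cc2ccc(Cl)cc2)c2ccccc12`: > 31600 nM (a limit)

Compound 3 stands at > 31600 nM, which is a limit of the assay and not a number. This is the limit of > 31600 nM in this assay, at which 2 of the 3 values shown sit.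

Compound 4 `COC(=O)CNCc1cn(Cc2ccc(Cl)cc2)c2ccccc12` is reached from compound 3 by one change: ((methoxycarbonyl)methyl)amino in place of hydrogen on a saturated chain carbon bound to an aromatic carbon. Within the data shown here, two measured steps bear on it. One is an at least 400-fold higher number from compound 1 to compound 3 (2.60 log units; beyond the scatter), and the other is an at least 400-fold higher number from compound 1 to compound 2 (2.60 log units; beyond the scatter). Both are large, so this assay responds strongly to what sits on this chain carbon. The remaining step, a step that the two limits leave unreadable from compound 2 to compound 3, adds nothing. Only compound 1 gives a number, with hydroxy on that carbon, while compound 2 shows that a larger group there does not by itself give activity. A lower number than for compound 3 is expected, but with much uncertainty and probably well short of compound 1.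

The expected step is an at least 6.3-fold lower number from compound 3 to compound 4 (0.80 log units; beyond the scatter). For compound 4 the estimated value is 5000 nM, with an expected range from 200 nM to 31600 nM.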

Compound 4, half-maximal inhibitory concentration: 5010 nM
Compound 4: the middle estimate sits 1.0-fold (0.00 log units) below what was measured, and the stated range covers the measured number.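

In this assay, ((methoxycarbonyl)methyl)amino gives a measurable value on this chain carbon, with an at least 6.3-fold lower number from compound 3 to compound 4 (0.79 log units; beyond the scatter) and an at least 6.3-fold lower number from compound 2 to compound 4 (0.79 log units; beyond the scatter). Activity at this position is therefore not confined to the hydroxy of compound 1, although the new group does not match it, with a 63-fold higher number from compound 1 to compound 4 (1.80 log units; beyond the scatter). Compound 2 and compound 3 each stand at a limit of the assay and not at a number, so the first two steps give only a minimum size: the limit of > 31600 nM in this assay, at which 2 of the 4 values shown sit.

The compounds shown leave open whether the nitrogen or the methoxycarbonyl part of the new group carries this activity, which a simple amine or a carboxylic acid in place of the methoxycarbonyl could separate. They also leave open how a longer chain between that nitrogen and the methoxycarbonyl would change the value.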